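The compounds below may be only part of what the source reports. "The series", "measured", "known", "first", "only" and "open" are said of these compounds alone.

Three compounds have been measured in a functional assay on BT-474 cells (Homo sapiens) for inhibition, read by fluorescence, with a stated time of 72 h; on this read-out higher numbers stand for weaker inhibition of growth and lower numbers for stronger inhibition of growth:
Compound 1 `CC(C)=CCn1cnc2c(Nc3cccc(Cl)c3)nc(N[C@H]3CC[C@H](N)CC3)nc21` gives 7000 nM.
Compound 2 `COc1ccc(Nc2nc(N[C@H]3CC[C@H](N)CC3)nc3c2ncn3CCC(C)C)c(OC)c1` gives 7900 nM.
Compound 3 `COc1cc(Nc2nc(N[C@H]3CC[C@H](N)CC3)nc3c2ncn3CCC(C)C)cc(OC)c1` gives 5900 nM.

Compound 3 has the lowest of the three numbers, but its gaps to compound 1 and to compound 2 both lie within the scatter, so no order among them can be claimed. For the measured compounds named here, the one measured step, a 1.3-fold lower number from compound 2 to compound 3 (0.13 log units; within the scatter), changed only the placing of two methoxy groups and stayed within the scatter.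

Compound 4 `CC(C)CCn1cnc2c(Nc3cccc(Cl)c3)nc(N[C@H]3CC[C@H](N)CC3)nc21` differs from compound 3 in this way: 3-chlorophenyl in place of 3,5-dimethoxyphenyl on a nitrogen on an aromatic ring. Going by the values given here, no measured step swaps the aryl group itself, so that step gives little guidance. Compound 1 carries the same 3-chlorophenyl group and its value sits close to compound 3, which suggests no step beyond the scatter. Compound 4 is therefore expected near 6500 nM, between 3000 nM and 15000 nM, an estimated step of a 1.1-fold higher number from compound 3 to compound 4 (0.04 log units; within the scatter).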

Compound 4, concentration for 50% growth inhibition: 3800 nM
Compound 4: middle estimate off by 1.7-fold (0.23 log units), on the high side; the measured number falls inside the stated range.
By their numbers in this assay, from the lowest: compounds 4, 3, 1 and 2 (each within the scatter of the next, the first and the last beyond it).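

The aryl group on a nitrogen on an aromatic ring now yields a step beyond the scatter, though a modest one: 3-chlorophenyl in place of 2,4-dimethoxyphenyl gives (a 2.1-fold lower number from compound 2 to compound 4 (0.32 log units; beyond the scatter)). In place of 3,5-dimethoxyphenyl, the same group stays within the scatter (a 1.6-fold lower number from compound 3 to compound 4 (0.19 log units; within the scatter)), as does isobutyl in place of 2-methylprop-1-en-1-yl on the chain (a 1.8-fold lower number from compound 1 to compound 4 (0.27 log units; within the scatter)). No measured evidence explains these steps. Still open, from the compounds shown here alone, is how an amine or a carboxylic acid on the aryl ring, or a longer chain in place of isobutyl, would read in this assay.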